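Indene in Place of Indane on the Piperazine Side Chain

The source may hold more compounds than are shown below. What is called first, only, known or untested is meant among the compounds shown, and "the series" means these compounds.

Compound 1 `c1ccc2c(c1)CC2CCCN1CCN(c2cccc3c2OCCO3)CC1`: 0.45 mg/kg
Compound 2 `c1ccc2c(c1)CC(CCN1CCN(c3cccc4c3OCCO4)CC1)C2`: 0.66 mg/kg

Of the compounds shown here, two have been measured in an assay for activation of Adrenergic receptor alpha-1 (Rattus norvegicus); a lower number here means that less compound is needed, a higher number that more compound is needed for the effect. Compound 1 gives 0.45 mg/kg, and compound 2 gives 0.66 mg/kg. Compound 2 has the higher of the two numbers, but the step of a 1.5-fold higher number from compound 1 to compound 2 (0.17 log units; within the scatter) lies within the scatter, so the two compounds cannot be told apart on these data.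

Compound 3 `C1=C(CCN2CCN(c3cccc4c3OCCO4)CC2)Cc2ccccc21` is the next compound to be measured. Relative to compound 2 the change is a group of 9 heavy atoms (9 carbon; one five-membered non-aromatic ring of carbon only, one six-membered aromatic ring of carbon only) in place of a group of 9 heavy atoms (9 carbon; one five-membered non-aromatic ring of carbon only, one six-membered aromatic ring of carbon only), on a saturated chain carbon, two bonds along the chain from an amine nitrogen in a ring. Within the data shown here, the only step measured so far, a 1.5-fold higher number from compound 1 to compound 2 (0.17 log units; within the scatter), exchanged one saturated carbocycle for another at the same place and produced no change beyond the scatter. Among the measured compounds shown here, no measured step bears on the introduction of a double bond outside the aromatic ring, so there is no direct precedent for the present change.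

Given the near-constancy seen across the one measured step, compound 3 is expected to stay close to compound 2, with an estimated step of a 1.1-fold lower number from compound 2 to compound 3 (0.04 log units; within the scatter) in this assay. Compound 3 is therefore estimated at 0.6 mg/kg, with a range from 0.25 mg/kg to 1.5 mg/kg.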

Compound 3, dose for half-maximal effect: 0.17 mg/kg
Estimate against measurement, compound 3: 3.5-fold (0.55 log units) above; the measured number lies below the stated range.
By their numbers in this assay, from the lowest: compound 3; then compounds 1 and 2 (each within the scatter of the next).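

In this assay, among these compounds, the step of a 3.9-fold lower number from compound 2 to compound 3 (0.59 log units; beyond the scatter) is the first at this place, on a saturated chain carbon, two bonds along the chain from an amine nitrogen in a ring, to lie beyond the scatter. The 2,3-dihydro-1H-inden-2-yl group and the group that replaces it have the same count of heavy atoms and the same ring types, and neither has a hydrogen-bond donor or acceptor, so the one counted difference is a double bond outside aromatic rings; the earlier exchange of one saturated carbocycle for another had shown no such separation. With the further step a 2.6-fold lower number from compound 1 to compound 3 (0.42 log units; beyond the scatter) also beyond the scatter, compound 3 has the lowest number of the three, and nothing available explains why this double bond goes with a lower number.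

What the compounds shown leave open is whether the lower number belongs to this double bond alone or would survive a methyl group on the five-membered ring or a longer chain. They also leave open whether a fully aromatic naphthyl group at this place would move the number in this assay further in the same direction.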